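The source may hold more compounds than are shown below. What is called first, only, known or untested is meant among the compounds shown, and "the series" means these compounds.

Compound 1 `C=C(C)[C@@H]1CC=C(Cn2cc(COc3cccc(C4NC(=O)NC(C)=C4C(=O)OCC)c3)nn2)CC1` is measured in a functional assay on 786-0 cells (Homo sapiens) for inhibition, read by sulforhodamine B assay, with a stated time of 48 h (on this read-out lower numbers stand for stronger inhibition of growth and higher numbers for weaker inhibition of growth), and in that setting compound 1 gives 39700 nM. Compound 2 `C=C(C)[C@@H]1CC=C(Cn2cc(COc3cc(C4NC(=O)NC(C)=C4C(=O)OCC)ccc3OC)nn2)CC1` carries methoxy in place of hydrogen on an aromatic carbon. In this assay compound 2 reaches only a limit of the assay, > 100000 nM. The step that this change made is an at least 2.5-fold higher number from compound 1 to compound 2 (0.40 log units; beyond the scatter). Compound 3 `C=C(C)[C@@H]1CC=C(Cn2cc(COc3cccc(C4NC(=O)NC5=C4C(=O)CC(C)(C)C5)c3)nn2)CC1` is built on a different core; how that core differs from the core of compound 1 is not broken down here. In this assay compound 3 likewise gives only a limit of the assay, > 100000 nM. Compound 4 `C=C(C)[C@@H]1CC=C(Cn2cc(COc3cc(C4NC(=O)NC5=C4C(=O)CC(C)(C)C5)ccc3OC)nn2)CC1` stands to compound 3 as compound 2 stands to compound 1, carrying (methoxy in place of hydrogen on an aromatic carbon), the same change at the same kind of place. Compound 4 has not been measured. Compound 3 already sits at the limit of > 100000 nM in this assay, at which 2 of the 3 values shown sit, and the same change gave an at least 2.5-fold higher number from compound 1 to compound 2 (0.40 log units; beyond the scatter). On that rests the expected step for compound 4 of a step that the limit leaves unreadable from compound 3 to compound 4, most likely leaving compound 4 at a limit again. The estimate for compound 4 in this assay is 150000 nM, expected between 80000 nM and 600000 nM.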

Compound 4, concentration for total growth inhibition: > 100000 nM
Compound 4: a limit, no number; the forecaster's own chance of this, stated with the estimate: 90%; the middle value lies beyond the limit too.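

In this assay compound 4 gives > 100000 nM, which is a limit of the assay and not a number. Compound 3 also stands at a limit, so no step from compound 3 to compound 4 can be read: the limit of > 100000 nM in this assay, at which 3 of the 4 values shown sit.

The compounds shown leave open whether methoxy in place of hydrogen changes growth inhibition at all on the core of compound 3.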